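Widening the amide group of compound 3

The source may report more compounds than this note shows. Statements on the series, on what has been measured and on what is new or still open speak of the compounds shown alone.

Compound 1 `CCn1c(C(=O)NCCN)ccc1C(CC)(CC)c1ccc(OCC(=O)C(C)(C)C)c(C)c1` gives 2500 nM 
Compound 2 `CCn1c(C(=O)NCCN(C)C)ccc1C(CC)(CC)c1ccc(OCC(O)C(C)(C)C)c(C)c1` gives 2600 nM 
Compound 3 `C#CCNC(=O)c1ccc(C(CC)(CC)c2ccc(OCC(O)C(C)(C)C)c(C)c2)n1CC` gives 4400 nM 

In an ADME assay on L02 cells (Homo sapiens) for cytotoxicity, read by MTT assay, with a stated time of 48 h (a lower number here means a stronger inhibitor, a higher number a weaker inhibitor), compound 3 gives 4400 nM and sits within the scatter of both other compounds, so the three cannot be ranked. Compound 4 `CCn1c(C(=O)N(CCC#N)CCC#N)ccc1C(CC)(CC)c1ccc(OCC(O)C(C)(C)C)c(C)c1` differs from compound 3 by a group of 9 heavy atoms (6 carbon, 3 nitrogen; no ring) in place of a group of 4 heavy atoms (3 carbon, 1 nitrogen; no ring), on a carbonyl carbon and by nothing else. Going by the values given here, the one measured step in this part of the molecule is a 1.7-fold higher number from compound 2 to compound 3 (0.23 log units; within the scatter) and it stays within the scatter. Among the compounds with values here, no measured compound carries the incoming group, so this is only a weak guide. In this assay the estimate means a 1.1-fold lower number from compound 3 to compound 4 (0.04 log units; within the scatter) and so no expected change beyond the scatter. Compound 4 is estimated at 4000 nM with an expected range of 1800 nM to 9000 nM for now.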

Compound 4, half-maximal inhibitory concentration: 1700 nM
Compound 4: middle estimate off by 2.4-fold (0.37 log units), on the high side; the whole stated range lies above it.
By their numbers in this assay, from the lowest: compounds 4, 1, 2 and 3 (each within the scatter of the next, the first and the last beyond it).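

In this assay, going by these compounds alone, this carbonyl carbon now shows a change that passes the scatter: a 2.6-fold lower number from compound 3 to compound 4 (0.41 log units; beyond the scatter) is the first such step here, though a modest one. The same group does not stand out against every neighbour, as a 1.5-fold lower number from compound 2 to compound 4 (0.18 log units; within the scatter) stays within the scatter. Nothing measured here explains the shift.

Compound 4 differs from compound 3 in both size and hydrogen-bond donor count, so the compounds shown cannot separate the two. A single longer chain ending in a nitrile, on an amide nitrogen that keeps its hydrogen, would bear on this.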